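From 4-chlorobenzyl to 2,6-difluorobenzyl on compound 2

The compounds below may be only part of what the source reports. "The series", "measured", "known", "first", "only" and "open" are said of these compounds alone.

In a functional assay on Bel-7402 cells (Homo sapiens) for antiproliferative activity, read by MTT assay, with a stated time of 72 h (on this read-out higher numbers stand for weaker inhibition and lower numbers for stronger inhibition), the measured compounds are these:
- compound 1 `C=C1C(=O)O[C@H]2[C@H]1CC/C(COC(=O)CCC(=O)NCCCCCCNC(=O)Cn1cc(F)c(=O)n(Cc3ccccc3)c1=O)=C\CC[C@@]1(C)O[C@@H]21` with 18300 nM
- compound 2 `C=C1C(=O)O[C@H]2[C@H]1CC/C(COC(=O)Cn1cc(F)c(=O)n(Cc3ccc(Cl)cc3)c1=O)=C\CC[C@@]1(C)O[C@@H]21` with 2560 nM

Compound 2 has the lower of the two numbers at 2560 nM and so shows the stronger inhibition. The gap to compound 1 at 18300 nM lies beyond the scatter.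

Compound 3 `C=C1C(=O)O[C@H]2[C@H]1CC/C(COC(=O)Cn1cc(F)c(=O)n(Cc3c(F)cccc3F)c1=O)=C\CC[C@@]1(C)O[C@@H]21` differs from compound 2 in one place (2,6-difluorophenyl in place of 4-chlorophenyl on a saturated chain carbon bound to an aromatic nitrogen), with 2,6-difluorophenyl in place of 4-chlorophenyl on a saturated chain carbon bound to an aromatic nitrogen. Within the data shown here, no two measured compounds differ in just one place, so the data hold no direct precedent for this change. With no measured guide to direction, the expectation in this assay is a step no larger than the scatter, and the value of compound 2 at 2560 nM serves as the anchor. The estimated change is a 1.2-fold higher number from compound 2 to compound 3 (0.07 log units; within the scatter) and it stays within that scatter. For compound 3 the expected value is 3000 nM with an estimated range from 1000 nM to 9000 nM in this assay once it is measured.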

Compound 3, half-maximal inhibitory concentration: 4500 nM
For compound 3 the middle estimate is 1.5-fold (0.18 log units) below the measured one; the measured number falls inside the stated range.
By their numbers in this assay, from the lowest: compounds 2 and 3 (each within the scatter of the next); then compound 1.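

Among these compounds, this is the first step that can be read at a single place, the saturated chain carbon bound to an aromatic nitrogen, and in this assay it gives a 1.8-fold higher number from compound 2 to compound 3 (0.24 log units; within the scatter). The position thus takes 2,6-difluorophenyl in place of 4-chlorophenyl, one chlorine giving way to two fluorines on the same six-membered aromatic ring of carbon, and the step stays within the scatter, so this pair does not separate the two groups in this read-out. No measured property of either group bears on the result, and the data offer no explanation for it.

Compound 1 differs from compound 2 and compound 3 in more than one place, so the contribution of its longer chain cannot be separated from that of its plain phenyl group. Going by these compounds, whether an aminophenyl group, a pyridine ring or a carboxylic acid on the phenyl ring at this same place would also stay within the scatter of compound 2 remains open.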